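The source may hold more compounds than are shown below. What is called first, only, known or untested is meant among the compounds shown, and "the series" means these compounds.

Measured in a functional assay on A549 cells (Homo sapiens) for cytotoxicity, read by MTT assay, with a stated time of 72 h; on this read-out higher numbers stand for weaker inhibition and lower numbers for stronger inhibition:
- compound 1 `COc1cc2ncnc(Nc3ccc(F)c(Cl)c3)c2cc1NC(=O)N/N=C/c1cccc(Br)c1`: 28100 nM
- compound 2 `COc1cc2ncnc(Nc3ccc(F)c(Cl)c3)c2cc1NC(=O)N/N=C/c1cc(OC)c(OC)c(OC)c1`: 32100 nM
- compound 3 `COc1cc2ncnc(Nc3ccc(F)c(Cl)c3)c2cc1NC(=O)N/N=C/c1ccc(O)c(Br)c1`: 28600 nM

The three compounds share a core and differ only in the aryl group on the carbon with a double bond to nitrogen. Compound 3, at 28600 nM, stands level with the other two, as none of the gaps among them exceeds the scatter.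

The next compound, compound 4 `CCN(CC)c1ccc(/C=N/NC(=O)Nc2cc3c(Nc4ccc(F)c(Cl)c4)ncnc3cc2OC)c(O)c1`, carries a new group at that same place: 4-(diethylamino)-2-hydroxyphenyl in place of 3-bromo-4-hydroxyphenyl on a carbon with a double bond to nitrogen. Its 4-(diethylamino)-2-hydroxyphenyl group replaces the 3-bromo-4-hydroxyphenyl group of compound 3.

Among the measured compounds shown here, three measured steps bear on this change. Two are exchanges of the whole aryl group, a 1.1-fold higher number from compound 1 to compound 2 (0.06 log units; within the scatter) and a 1.1-fold lower number from compound 2 to compound 3 (0.05 log units; within the scatter), and the third is the addition of a hydroxy group, a 1.0-fold higher number from compound 1 to compound 3 (0.01 log units; within the scatter). All three are small and within the scatter, so these exchanges have so far left the number in this assay essentially unmoved. For the measured compounds named here, no measured compound carries a diethylamino group, however, so the data do not test that part of the change, and the range has to stay wide.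

No step beyond the scatter is expected, and the estimated step is a 1.1-fold lower number from compound 3 to compound 4 (0.06 log units; within the scatter). For compound 4 the expected value is 25000 nM, within an estimated range of 9000 nM to 60000 nM.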

Compound 4, half-maximal inhibitory concentration: 27300 nM
For compound 4 the middle estimate is 1.1-fold (0.04 log units) below the measured one; low and high end bracket the measured number.
By their numbers in this assay, from the lowest: compounds 4, 1, 3 and 2 (each within the scatter of the next).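

In this assay, the 4-(diethylamino)-2-hydroxyphenyl group stands level with each of the three aryl groups it can be compared with (a 1.0-fold lower number from compound 3 to compound 4 (0.02 log units; within the scatter); a 1.2-fold lower number from compound 2 to compound 4 (0.07 log units; within the scatter); a 1.0-fold lower number from compound 1 to compound 4 (0.01 log units; within the scatter)). This extends the flat picture to a group of 12 heavy atoms that carries nitrogen and no bromine, whereas the 3-bromo-4-hydroxyphenyl group it replaces has 8 heavy atoms and no nitrogen, so a diethylamino group on the aryl ring, untested until now, does not separate compound 4 from the rest of the series. No measurement is available that would explain why the number stays level across these exchanges.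

The four compounds therefore leave open whether any group on the carbon with a double bond to nitrogen can move the number beyond the scatter, for instance an aryl ring bearing a carboxylic acid or a primary amine, or a saturated ring such as piperidine in place of the aryl ring. The compounds also leave open how the number responds to changes elsewhere, since the shared core and the chain leading to that carbon stay the same throughout.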